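Swapping the end ring of a methylated growth inhibitor

The source may hold more compounds than are shown below. What is called first, only, known or untested is meant among the compounds shown, and "the series" means these compounds.

- Compound 1 `Cc1ccc2[nH]c(-c3ccc(-c4ccc(-c5cccc(Cl)c5)cc4)cc3)nc2c1` gives 2740 nM
- Compound 2 `Clc1cccc(-c2ccc(-c3ccc(-c4nc5ccccc5[nH]4)cc3)cc2)c1` gives 100000 nM
- Compound 3 `Oc1cccc2[nH]c(-c3ccc(-c4ccc(-c5ccc(C(F)(F)F)cc5)cc4)cc3)nc12` gives 3200 nM

In a functional assay on HOP-62 cells (Homo sapiens) for inhibition, read by sulforhodamine B assay (on this read-out higher numbers stand for weaker inhibition of growth and lower numbers for stronger inhibition of growth), compound 1 gives 2740 nM and has the lowest of the three numbers. Its value and that of compound 3 lie within the usual scatter of each other, while compound 2 stands far higher.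

Compound 4 `Cc1ccc2[nH]c(-c3ccc(-c4ccc(-c5ccc(OC(F)(F)F)cc5)cc4)cc3)nc2c1` keeps the core and the methyl of compound 1 and changes only the end ring. The change is 4-(trifluoromethoxy)phenyl in place of 3-chlorophenyl on an aromatic carbon and in words it puts 4-(trifluoromethoxy)phenyl in place of 3-chlorophenyl on an aromatic carbon.

Within the data shown here, the one measured step is a 36-fold higher number from compound 1 to compound 2 (1.56 log units; beyond the scatter) and it is large, but it concerns the methyl, which compound 4 retains. Among the measured compounds shown here, no measured step changes the end ring alone. Compound 3 offers a loose guide: it carries a fluorinated group on its end ring and a hydroxyl rather than a methyl on its core, and it gives 3200 nM in this read-out. With so few compounds, any expectation stays uncertain and the range must be wide.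

The estimated outcome in this assay is a 1.1-fold higher number from compound 1 to compound 4 (0.04 log units; within the scatter) and no change beyond the scatter is expected. For compound 4 the estimated value is 3000 nM with an expected range from 1000 nM to 12000 nM on this reasoning.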

Compound 4, concentration for 50% growth inhibition: 24200 nM
Beside the measured number, compound 4's estimate is 8.1-fold (0.91 log units) below it, outside the stated range (above it).
By their numbers in this assay, from the lowest: compounds 1 and 3 (each within the scatter of the next); then compound 4; then compound 2.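

The end ring is not a silent position: with the shared core and the methyl held fixed in this assay, replacing 3-chlorophenyl with 4-(trifluoromethoxy)phenyl gives an 8.8-fold higher number from compound 1 to compound 4 (0.95 log units; beyond the scatter) and so weakens growth inhibition. This is the first step shown that changes the end ring alone, whereas the earlier step, a 36-fold higher number from compound 1 to compound 2 (1.56 log units; beyond the scatter), concerned only the methyl on the core, so both ends of the molecule now have a measured effect on this read-out. No supporting measurement is available to explain why this swap weakens growth inhibition.

The swap changes both the group on the end ring and the place it occupies, so these compounds cannot show whether the loss follows the trifluoromethoxy group, the removal of chlorine or the new location on the ring. As far as these compounds go, how an end ring carrying an amine or a carboxylic acid would behave also remains open, as does whether such a group would bring the number back towards that of compound 1.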